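The source may report more compounds than this note shows. Statements on the series, on what has been measured and on what is new or still open speak of the compounds shown alone.

Of the compounds shown here, three have so far been measured in a functional assay on the whole organism with Rattus norvegicus as the target, at a dose of 20 mg/kg by the oral route; on this read-out lower numbers stand for less inhibition and higher numbers for more inhibition at the one dose given (going by the name of the read-out). Compound 1 `Cc1cccc2c1CC/C2=C\C(=O)NC1CC1` gives 15%. Compound 2 `CNC(=O)/C=C1\CCc2ccc(Br)cc21` gives 44%, and compound 3 `O=C(/C=C1\CCc2ccc(F)cc21)NCC1CC1` gives 0%. Among these three numbers compound 1 stands second highest: compound 3 lies lower, beyond the usual scatter, and compound 2 lies higher, also beyond it.

Compound 4 `O=C(/C=C1\CCc2c(Cl)cccc21)NC1CC1` has not yet been measured. It differs from compound 1 in a single place: chloro in place of methyl on an aromatic carbon. Among the compounds with values here, no measured pair shows this exchange on its own, so nothing is known about its effect here. Any step a number 5 percentage points higher from compound 1 to compound 4 (within the scatter) is expected to stay within the scatter, with no clear direction. Compound 4 is estimated at 20%, with a range from 0% to 45%.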

Compound 4, a percentage reported as inhibition, in the whole organism at one dose (the size of the read-out at that dose, not a potency): 28%
Compound 4: the middle estimate sits 8 percentage points below what was measured, and the stated range covers the measured number.
By their numbers in this assay, from the lowest: compound 3; then compound 1; then compound 4; then compound 2.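

In this assay, chloro in place of methyl on this aromatic carbon gives a number 13 percentage points higher from compound 1 to compound 4 (beyond the scatter). Within the data shown here, this is the first pair that differs in one place only, and it shows that exchanging a single group at this position can shift the number beyond the scatter, though only modestly. Nothing available explains why the number rises with chloro.

On these data alone, what a methoxy group or a plain hydrogen on this same carbon would give remains open. So does whether this exchange would give a similar step with a longer chain on the amide nitrogen.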